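A few compounds are considered here, and "the series" means these few. Any claim that something is new, unique, unknown or untested is made for them only; others in the source may bear on it.

Measured compounds in an assay on Sf9 cells for inhibition of serine/threonine-protein kinase 4 (Homo sapiens), read by luminescence and ADP-Glo, with a stated time of 1 h, in the presence of a further agent that is not named here; on this read-out lower numbers stand for stronger inhibition and higher numbers for weaker inhibition:
- compound 1, `CN1C(=O)C(c2cccc(F)c2)N(C)c2nc(Nc3ccc(S(N)(=O)=O)cc3)ncc21`, gives 134 nM
- compound 2, `CN1C(=O)C(c2cccc(Cl)c2)N(C)c2nc(Nc3ccc(S(N)(=O)=O)cc3)ncc21`, gives 989 nM
- compound 3, `CCc1ccccc1C1C(=O)N(C)c2cnc(Nc3ccc(S(N)(=O)=O)cc3)nc2N1C`, gives 51 nM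

Compound 3 stands lowest of the three in this assay; the step of a 2.6-fold lower number from compound 1 to compound 3 (0.42 log units; beyond the scatter) and the step of a 19-fold lower number from compound 2 to compound 3 (1.29 log units; beyond the scatter) both lie beyond the scatter, so compound 3 is the most potent of the measured set.

Compound 4 is `CN1C(=O)C(c2ccccc2Br)N(C)c2nc(Nc3ccc(S(N)(=O)=O)cc3)ncc21`. Relative to compound 3 the change is bromo in place of ethyl on an aromatic carbon. Going by the values given here, no measured step covers this exact change. Among the compounds with values here, the only halogen-to-halogen comparison is a 7.4-fold higher number from compound 1 to compound 2 (0.87 log units; beyond the scatter), which shows that a swap of halogen at the aromatic ring can shift the read-out by a modest amount; the ring swaps a 2.6-fold lower number from compound 1 to compound 3 (0.42 log units; beyond the scatter) and a 19-fold lower number from compound 2 to compound 3 (1.29 log units; beyond the scatter) concern a different kind of change and bear on it only indirectly. Within the data shown here, with no direct precedent for a halogen at the place of the ethyl, a modest loss against compound 3 is expected, roughly a 2.9-fold higher number from compound 3 to compound 4 (0.47 log units; beyond the scatter), but the range must stay wide. Compound 4 is therefore estimated at 150 nM, between 40 nM and 600 nM.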

Compound 4, half-maximal inhibitory concentration: 57 nM
The estimate for compound 4 lay 2.6-fold (0.42 log units) above the measured number; measured number inside the range.
By their numbers in this assay, from the lowest: compounds 3 and 4 (each within the scatter of the next); then compound 1; then compound 2.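

In this assay, on an aromatic carbon ortho to a large group, bromo and ethyl give numbers that cannot be told apart (a 1.1-fold higher number from compound 3 to compound 4 (0.05 log units; within the scatter)), so a single bromine serves here as well as the two-carbon ethyl. The 2-bromophenyl group also keeps the advantage seen for 2-ethylphenyl over the other two aryl groups (a 2.4-fold lower number from compound 1 to compound 4 (0.37 log units; beyond the scatter); a 17-fold lower number from compound 2 to compound 4 (1.24 log units; beyond the scatter)), which means compound 3 no longer stands alone at the low end of the series. Nothing available explains why the two groups match.

On these data alone, whether this place also tolerates an amine, a carboxylic acid or a longer chain such as butyl remains open. No pair shown carries the same group at 2- and 3-positions of the phenyl ring, so the contribution of placement alone is unresolved.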